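Moving the pyridine nitrogen in a pyrazoline anti-inflammatory series

The compounds below may be only part of what the source reports. "The series", "measured", "known", "first", "only" and "open" are said of these compounds alone.

Of the compounds shown here, three have been tested in a functional assay on the whole organism (strain Charles Foster albino) for inhibition, with Rattus norvegicus as the target, read by paw edema, with stated times of 30 min and 3 h, at a dose of 50 mg/kg by the oral route; a higher number here means more inhibition at the dose given (going by the name of the read-out), a lower number less inhibition. Compound 1 `COc1cc(-c2nc(-c3cnccn3)no2)ccc1O` gives 26% in this assay. Compound 2 `CN(C)c1ccc(C2CC(c3ccccn3)=NN2c2ccccc2)cc1` gives 35%, and compound 3 `CN(C)c1ccc(C2CC(c3ccccn3)=NN2)cc1` gives 18%. Within the data shown here, compound 2 holds the highest of the three numbers, yet its gap to compound 1 lies within the scatter, so the two cannot be ordered; only compound 3 sits clearly lower, as the single one-place step shows: a number 17 percentage points lower from compound 2 to compound 3 (beyond the scatter).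

Compound 4 `CN(C)c1ccc(C2CC(c3ccncc3)=NN2c2ccccc2)cc1` differs from compound 2 by a rearrangement of the same atoms: pyridin-4-yl in place of pyridin-2-yl on a carbon with a double bond to nitrogen. Among the measured compounds shown here, no measured step speaks to this change. For the measured compounds named here, the only step known, from compound 2 to compound 3, concerns the ring nitrogen and not the pyridine, so it offers no guide here. With nothing to suggest a shift either way, the expectation is that compound 4 behaves much like compound 2, with a step of a number 2 percentage points lower from compound 2 to compound 4 (within the scatter), not beyond the scatter. Compound 4 is therefore estimated at 33% in this assay, within a range from 18% to 48%.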

Compound 4, a percentage reported as inhibition, in the whole organism at one dose (the size of the read-out at that dose, not a potency): 32%
For compound 4 the middle estimate is 1 percentage points above the measured one; low and high end bracket the measured number.
By their numbers in this assay, from the lowest: compounds 3, 1, 4 and 2 (each within the scatter of the next, the first and the last beyond it).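

In this assay the step from pyridin-2-yl to pyridin-4-yl on the carbon with a double bond to nitrogen comes to a number 3 percentage points lower from compound 2 to compound 4 (within the scatter) and so gives no ground for ordering the two compounds. Among these compounds, the earlier compounds spoke only to the ring nitrogen, with a number 17 percentage points lower from compound 2 to compound 3 (beyond the scatter) for hydrogen in place of phenyl, whereas this pair gives the first reading at the carbon position and shows that moving the pyridine attachment, with the same atoms and the same counts, leaves no readable mark on inhibition at this dose. No supporting measurement bears on why the two compounds cannot be told apart, so the finding stays an observation from one pair at a single dose.

The compounds shown leave open how pyridin-3-yl would read at this carbon, and whether a plain phenyl ring or a pyridine carrying a methoxy or carboxylic acid group would stay level with these two. They also leave open whether the same move would read alike with hydrogen on the ring nitrogen, as in compound 3 , since that pairing is not among those shown.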